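The source may hold more compounds than are shown below. What is called first, only, known or untested is meant among the compounds shown, and "the series" means these compounds.

Compound 1 `COc1ccc(-c2cnc(NC(=O)c3cccc(OC)c3)n2C)cc1` – in a toxicity assay on THP-1 cells (Homo sapiens) for inhibition (on this read-out lower numbers stand for higher toxicity in this test and higher numbers for lower toxicity in this test), compound 1 gives > 100000 nM
Compound 2 `Cc1ccccc1-c1cnc(NC(=O)c2ccc(F)cc2)n1C` – compound 2 gives > 50000 nM
Compound 3 `Cn1c(-c2cccc(Br)c2)cnc1NC(=O)c1ccc(F)cc1` – compound 3 gives > 50000 nM

Each of these values is a limit of the test, not a measured number. Compound 1 sits at the limit of > 100000 nM in this assay, at which 1 of the 3 values shown sits, the highest level the test reports. Compounds 2 and 3 sit at the limit of > 50000 nM in this assay, at which 2 of the 3 values shown sit. Compound 4 `COc1ccc(-c2cnc(NC(=O)c3cccc(C#N)c3)n2C)cc1` differs from compound 1 by cyano in place of methoxy on an aromatic carbon. Among the measured compounds shown here, the only measured step, a step that the two limits leave unreadable from compound 2 to compound 3, runs between two limits, so its size is unreadable, and it changes a different part of the molecule. For the measured compounds named here, no measured step therefore bears on the change to compound 4, and no step beyond the scatter is expected in this assay. Compound 4 is expected at about 100000 nM, within 50000 nM to 200000 nM, a step of a number no higher from compound 1 to compound 4 (the limit leaves the size open), most likely again reported only as a limit.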

Compound 4, half-maximal cytotoxic concentration: > 100000 nM
Compound 4: a limit, no number; the forecaster's own chance of this, stated with the estimate: 85%; the middle value lies on the limit itself.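

The step between compound 1 and compound 4 cannot be read, as both values are limits and not numbers. The compounds shown leave open whether any change to the shared core would give a measured number in this assay.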